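The compounds below may be only part of what the source reports. "The series", "measured", "known", "first", "only" and "open" are said of these compounds alone.

Measured in a functional assay on cells (Cancer cell lines, Homo sapiens) for inhibition; a higher number here means a weaker inhibitor of growth, a lower number a stronger inhibitor of growth:
- compound 1 `Cc1cn2c(/C=N/NC(=N)N)c(-c3ccsc3)nc2s1`: 41700 nM
- compound 2 `N=C(N)N/N=C/c1c(-c2cc(Cl)sc2Cl)nc2n1CCS2`: 22400 nM
- compound 3 `N=C(N)N/N=C/c1c(-c2ccsc2)nc2sccn12`: 30200 nM

Compound 3, at 30200 nM, lies within the usual scatter of both other compounds, so its place among these three numbers cannot be told with confidence.

Compound 4 `N=C(N)N/N=C/c1c(-c2cccs2)nc2sccn12` has the same atoms as compound 3, joined differently, with thiophen-2-yl in place of thiophen-3-yl on an aromatic carbon.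

Within the data shown here, only one measured step links two compounds that differ in one place: a 1.4-fold lower number from compound 1 to compound 3 (0.14 log units; within the scatter). That step is a different change, hydrogen in place of methyl on an aromatic carbon, and it stays within the scatter. Among the measured compounds shown here, no measured pair makes the thiophene swap itself, so the data offer no direct evidence for it. Compound 2, at 22400 nM, differs from compound 3 in more than one place and gives no clean comparison. The three values still lie close together, so no step beyond the scatter is expected in this assay, and neither direction is favoured. The expected change is a 1.0-fold lower number from compound 3 to compound 4 (0.00 log units; within the scatter).

For compound 4 the expected value is 30000 nM, with an estimated range of 15000 nM to 60000 nM.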

Compound 4, concentration for total growth inhibition: 29500 nM
For compound 4 the middle estimate is 1.0-fold (0.01 log units) above the measured one; measured number inside the range.
By their numbers in this assay, from the lowest: compounds 2, 4, 3 and 1 (each within the scatter of the next).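

In this assay, joining the thiophene through a different ring carbon gives a 1.0-fold lower number from compound 3 to compound 4 (0.01 log units; within the scatter), so the two compounds cannot be told apart in this read-out. Among these compounds, this is the first measured step at this position, on an aromatic carbon of the five-membered aromatic ring with 2 nitrogen; the earlier step, hydrogen in place of methyl, concerned a different change. It shows that, for this pair, thiophen-2-yl and thiophen-3-yl can stand in for each other here without a difference that rises above the scatter, although nothing measured here explains why the two read alike.

Both groups are thiophene rings with the same atoms, so this pair says little about how far the position would accept a truly different group, such as a phenyl ring, a pyridine ring or an open butyl chain. It also leaves open whether an amine or a carboxylic acid carried on the thiophen-2-yl ring would bring compound 4 to a number beyond the scatter, in either direction.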